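A few compounds are considered here, and "the series" means these few. Any claim that something is new, unique, unknown or untested is made for them only; others in the source may bear on it.

Measured in a functional assay on MIA PaCa-2 cells (Homo sapiens) for inhibition, read by MTT assay, with a stated time of 7 days; on this read-out lower numbers stand for stronger inhibition and higher numbers for weaker inhibition:

compound 1, `O=C([C@@H]1CCCN(S(=O)(=O)c2ccc(S(=O)(=O)C3COC3)cc2)C1)N1CCC(F)(F)CC1`: 110 nM
compound 2, `CCN(CC)S(=O)(=O)c1ccc(S(=O)(=O)N2CCC[C@@H](C(=O)NC3COC3)C2)cc1`: 2340 nM
compound 3, `CCN(CC)S(=O)(=O)c1ccc(S(=O)(=O)N2CCC[C@@H](C(=O)N[C@@H]3CCOC3)C2)cc1`: 750 nM

Compound 1 stands lowest of the three numbers; compound 3 is nearest, compound 2 furthest, both beyond the scatter. Compound 4, `O=C([C@@H]1CCCN(S(=O)(=O)c2ccc(S(=O)(=O)N3CC[C@H](O)C3)cc2)C1)N1CCC(F)(F)CC1`, is not yet measured. It differs from compound 1 in one place: 3-hydroxypyrrolidin-1-yl in place of oxetan-3-yl on a sulfonyl sulfur.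

Among the measured compounds shown here, the one step in which two measured compounds differ in a single place, a 3.1-fold lower number from compound 2 to compound 3 (0.49 log units; beyond the scatter), concerns a ring on an amide-type nitrogen and not the group on the sulfonyl sulfur, so it does not bear directly on the change from compound 1 to compound 4. For the measured compounds named here, compounds 2 and 3 carry a different substituent on that sulfonyl sulfur than compound 1, but they also differ from compound 1 at the amide, so their two values show only that the combined changes give higher numbers; nothing isolates the sulfonyl-side change. The expectation therefore rests on the absence of a guiding step: a modest change in either direction, a 2.0-fold higher number from compound 1 to compound 4 (0.30 log units; within the scatter), is expected. Compound 4 is estimated at 220 nM, with a range from 60 nM to 800 nM.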

Compound 4, half-maximal inhibitory concentration: 590 nM
Compound 4: middle estimate off by 2.7-fold (0.43 log units), on the low side, within the range that was stated.
By their numbers in this assay, from the lowest: compound 1; then compounds 4 and 3 (each within the scatter of the next); then compound 2.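

In this assay, among the compounds shown here, a 5.4-fold higher number from compound 1 to compound 4 (0.73 log units; beyond the scatter) is the first step that isolates the group on the sulfonyl sulfur on the core of compound 1, and it lies beyond the scatter, so the number at this position responds to the group placed there. The exchange to 3-hydroxypyrrolidin-1-yl brings two more heavy atoms, a five-membered ring and a hydrogen-bond donor, and compound 4 still reads 590 nM in this assay. No measurement on these groups is available to account for the step.

Still open, as far as these compounds go, is which part of the exchange goes with the higher number, a question that a plain pyrrolidin-1-yl or a tetrahydrofuran-3-yl on the sulfonyl sulfur would address. Also open, from the compounds shown here alone, is whether the defined stereocentre matters, which the mirror-image 3-hydroxypyrrolidin-1-yl would test.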